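Methyl for methoxy on a nucleoside core: cell growth inhibition

The compounds below may be only part of what the source reports. "The series", "measured", "known", "first", "only" and "open" are said of these compounds alone.

Measured compounds:
compound 1 `COc1ncnc2c1c(-c1ccsc1)cn2[C@@H]1O[C@H](CO)[C@@H](O)[C@H]1O` — 64300 nM
compound 2 `COc1ncnc2c1c(-c1cccs1)cn2[C@@H]1O[C@H](CO)[C@@H](O)[C@H]1O` — 62800 nM

In an ADME assay on BJ cells (Homo sapiens), read by MTT assay, with a stated time of 72 h (on this read-out lower numbers stand for stronger inhibition and higher numbers for weaker inhibition), compound 1 gives 64300 nM, and compound 2 gives 62800 nM. Within the data shown here, these are the only two numbers available, and they sit together: the step of a 1.0-fold lower number from compound 1 to compound 2 (0.01 log units; within the scatter) shows that exchanging one thiophene attachment for the other leaves the read-out where it was. Compound 1 therefore stands in the same place as compound 2 on this read-out.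

Compound 3 `Cc1ncnc2c1c(-c1ccsc1)cn2[C@@H]1O[C@H](CO)[C@@H](O)[C@H]1O` differs from compound 1 at a different site: methyl in place of methoxy on an aromatic carbon. Among the measured compounds shown here, no measured step touches this position, so the change is untested here. For the measured compounds named here, the one step on record, from compound 1 to compound 2, concerns another part of the molecule and was within the scatter, so it offers no guide to direction. With nothing pointing either way, the expectation for compound 3 in this assay is a step of about a 1.1-fold lower number from compound 1 to compound 3 (0.03 log units; within the scatter), that is, no movement beyond the scatter. The estimate for compound 3 is 60000 nM, within a range from 20000 nM to 150000 nM.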

Compound 3, half-maximal inhibitory concentration: 96900 nM
Compound 3: middle estimate off by 1.6-fold (0.21 log units), on the low side; the measured number falls inside the stated range.
By their numbers in this assay, from the lowest: compounds 2, 1 and 3 (each within the scatter of the next).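

The earlier compounds shown here varied only the thiophene attachment, so they said nothing about this site, an aromatic carbon of a six-membered aromatic ring with 2 nitrogen, next to the ring nitrogen. In this assay, methyl in place of methoxy gives a 1.5-fold higher number from compound 1 to compound 3 (0.18 log units; within the scatter), so the read-out does not separate the two groups, even though the change removes an oxygen and, with it, the 1 hydrogen-bond acceptor that methoxy carries. No measurement shown here explains this outcome or links it to any property of either group.

Methoxy and methyl are only two small groups, so it remains open whether an amine, a chlorine atom or a longer chain such as propyl at the same place would leave the number within the scatter or shift it clearly. Going by these compounds, it is also open whether methyl behaves the same way when the thiophene is attached as thiophen-2-yl, as in compound 2, and whether the same swap matters in any cell type other than the one tested here.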